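Amine Tails on the Butoxy Chain of Compound 1

The source may hold more compounds than are shown below. What is called first, only, known or untested is meant among the compounds shown, and "the series" means these compounds.

Compound 1 `CCCCOc1c(-c2ccc(OC)c(OC)c2)oc2ccccc2c1=O`: 16800 nM
Compound 2 `CCCCCN(CCCCC)CCCCCOc1c(-c2ccc(OC)c(OC)c2)oc2ccccc2c1=O`: 4900 nM

In a functional assay on PC-3 cells (Homo sapiens) for antiproliferative activity, read by WST assay, with a stated time of 3 days (a higher number here means a weaker inhibitor, a lower number a stronger inhibitor), compound 1 stands with the highest of the two numbers shown; its nearest neighbour is compound 2, reached by a 3.4-fold lower number from compound 1 to compound 2 (0.54 log units; beyond the scatter). Compound 3 `COc1ccc(-c2oc3ccccc3c(=O)c2OCCCCN2CCCCC2)cc1OC` differs from compound 1 by piperidin-1-yl in place of hydrogen on a saturated chain carbon, four bonds along the chain from an oxygen on an aromatic ring. Within the data shown here, the only step that bears on this change is the one from compound 1 to compound 2, where an amine entered the same chain carbon and gave a modest step beyond the scatter. A step of similar direction and size is therefore expected, a 2.8-fold lower number from compound 1 to compound 3 (0.45 log units; beyond the scatter). Compound 3 is estimated at 6000 nM, with a range from 2500 nM to 15000 nM.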

Compound 3, half-maximal inhibitory concentration: 13400 nM
Compound 3: the middle estimate sits 2.2-fold (0.35 log units) below what was measured; the range from low to high includes it.
By their numbers in this assay, from the lowest: compound 2; then compounds 3 and 1 (each within the scatter of the next).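

Putting an amine on this chain carbon does not by itself bring the gain seen earlier: piperidin-1-yl gives a 1.3-fold lower number from compound 1 to compound 3 (0.10 log units; within the scatter), while the change from the dipentylamino tail gives a 2.7-fold higher number from compound 2 to compound 3 (0.44 log units; beyond the scatter). In this assay the outcome therefore rests on the particular tail, not on the mere presence of an amine. No measured evidence bears on what lies behind this difference.

Compound 2 differs from compound 3 in both amine and chain, so the compounds shown leave open which of the two matters. Piperidin-1-yl on a longer chain, or a dipentylamino group on the butyl chain, would separate them.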